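A few compounds are considered here, and "the series" means these few. Any claim that something is new, unique, unknown or untested is made for them only; others in the source may bear on it.

In a functional assay on A549 cells (Homo sapiens) for inhibition, read by MTT assay (on this read-out higher numbers stand for weaker inhibition and lower numbers for stronger inhibition), compound 1 `CCCCCCCCn1cc(/C=C/C(=O)c2ccc(NC(=O)CN3CCN(c4ccccc4)CC3)cc2)nn1` gives 52400 nM. Compound 2 `O=C(CN1CCN(c2ccccc2)CC1)Nc1ccc(C(=O)/C=C/c2cn(Cc3ccc(Br)cc3)nn2)cc1` gives 42100 nM in this assay. The two compounds differ in one place: a 1.2-fold lower number from compound 1 to compound 2 (0.10 log units; within the scatter). For the measured compounds named here, compound 2 thus holds the lower of the two numbers known so far, but with compound 1 as its only neighbour, and that neighbour within the scatter, the two cannot be told apart on these measurements.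

Compound 3 `O=C(CN1CCN(c2ccc([N+](=O)[O-])cc2)CC1)Nc1ccc(C(=O)/C=C/c2cn(Cc3ccc(Br)cc3)nn2)cc1` has not yet been measured. It differs from compound 2 only in that (nitro in place of hydrogen on an aromatic carbon). Going by the values given here, the one measured step concerns a different part of the shared core, the group carried on the saturated chain carbon bound to an aromatic nitrogen, and that step stayed within the scatter; no measured step touches the ring that receives the nitro group. There is therefore nothing in the data to suggest a change in either direction, and the expected step is a 1.0-fold lower number from compound 2 to compound 3 (0.00 log units; within the scatter), that is, none beyond the scatter. As far as these compounds go, compound 3 is accordingly estimated at 42000 nM in this assay, with a range from 15000 nM to 120000 nM, the width reflecting that the change is untested here.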

Compound 3, half-maximal inhibitory concentration: 45500 nM
Estimate against measurement, compound 3: 1.1-fold (0.03 log units) below; the measured number falls inside the stated range.
By their numbers in this assay, from the lowest: compounds 2, 3 and 1 (each within the scatter of the next).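

For the compounds shown here, the change from phenyl to 4-nitrophenyl, on an aromatic carbon para to a large group, gives in this assay a 1.1-fold higher number from compound 2 to compound 3 (0.03 log units; within the scatter) and is the first measured change on this ring. Nitro, with its 3 heavy atoms, can therefore replace hydrogen here without a difference that these measurements can resolve, and the same holds for the earlier change at the other varied place, a 1.2-fold lower number from compound 1 to compound 2 (0.10 log units; within the scatter), so neither of the two places has yet shown a step beyond the scatter. No independent measurement is available to explain this result.

As far as these compounds go, what remains open is whether this position responds at all, since a single substituent cannot show whether a different one, such as an amine, a carboxylic acid or a methoxy group, would produce a step beyond the scatter. It is also unknown whether nitro would behave the same way on another carbon of this ring, or whether it would do so with the heptyl group of compound 1 in place of 4-bromophenyl.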